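Dropping the Methyl Group from Compound 1

A few compounds are considered here, and "the series" means these few. Any claim that something is new, unique, unknown or untested is made for them only; others in the source may bear on it.

Measured so far:
compound 1 `CCS(=O)(=O)Nc1cccc(Cc2c[nH]cn2)c1C`: 69%
compound 2 `CS(=O)(=O)Nc1cccc2c1CCCC2C1=NCCN1`: 87%

In a functional assay on Urethra with Alpha-1A adrenergic receptor (Oryctolagus cuniculus) as the target (on this read-out higher numbers stand for larger maximal responses and lower numbers for smaller maximal responses), compound 1 stands lowest of the two numbers, while compound 2 reaches 87%, a value higher by a margin beyond the scatter. Compound 3 `CCS(=O)(=O)Nc1cccc(Cc2c[nH]cn2)c1` has not yet been measured. It differs from compound 1 in a single place: hydrogen in place of methyl on an aromatic carbon. Among the compounds with values here, no pair of measured compounds shows a change of this kind, so its effect is unknown. Compound 3 is expected to give about 70%, with a likely range from 52% to 88%. The expected change, a number 1 percentage points higher from compound 1 to compound 3 (within the scatter), is estimated to stay within the usual scatter, in no clear direction.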

Compound 3, largest response reached (reported as efficacy), in percent of the reference or control that the assay uses: 80%
Compound 3: middle estimate off by 10 percentage points, on the low side; low and high end bracket the measured number.
By their numbers in this assay, from the lowest: compound 1; then compounds 3 and 2 (each within the scatter of the next).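

In this assay, within the data shown here, replacing the methyl with hydrogen on this aromatic carbon, ortho to the (1H-imidazol-4-yl)methyl group and the (ethylsulfonyl)amino group, gives a modest rise, a number 11 percentage points higher from compound 1 to compound 3 (beyond the scatter), and this is the first step read at this position. On this single pair, the methyl is not required for the maximal response. No available measurement accounts for the step.

From the compounds shown here alone, whether chlorine, methoxy or ethyl on this carbon would give a larger or smaller response stays open. This one pair also cannot show whether the step would recur with another group in place of the (ethylsulfonyl)amino group.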